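This account rests on a few compounds, and the source may have more. Where it says the series, first, only, none or still open, it means among the compounds named here.

In a functional assay on LoVo cells (Homo sapiens) for inhibition, read by MTT assay, with a stated time of 72 h (on this read-out lower numbers stand for stronger inhibition and higher numbers for weaker inhibition), compound 1 (`C=C(Br)C(=O)Nc1cccc(/C=C/C(=O)Nc2ccccc2)c1`) gives 3900 nM and compound 2 (`C=C(Br)C(=O)Nc1cccc(/C=C/C(=O)Nc2ccc(F)cc2)c1`) gives 4800 nM while compound 3 (`C=C(Br)C(=O)Nc1cccc(/C=C/C(=O)Nc2ccc(C)cc2)c1`) gives 1500 nM as the lowest of the three numbers. The next change leads to compound 4 (`C=C(Br)C(=O)Nc1cccc(/C=C/C(=O)Nc2ccc(OCC)cc2)c1`) and puts ethoxy in place of methyl on an aromatic carbon para to a large group.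

Three measured steps at this place bear on it. The step of a 1.2-fold higher number from compound 1 to compound 2 (0.09 log units; within the scatter) is fluoro in place of hydrogen, the step of a 2.6-fold lower number from compound 1 to compound 3 (0.41 log units; beyond the scatter) is methyl in place of hydrogen and the step of a 3.2-fold lower number from compound 2 to compound 3 (0.51 log units; beyond the scatter) is methyl in place of fluoro. None of them involves ethoxy, so the data give no firm direction for this change. In this assay a step no larger than these modest ones is expected, most likely one within the scatter, with a slight lean to a higher number. The expected step is a 1.3-fold higher number from compound 3 to compound 4 (0.12 log units; within the scatter) on this estimate. For compound 4 the estimated value is 2000 nM with an expected range of 700 nM to 6000 nM in this read-out.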

Compound 4, half-maximal inhibitory concentration: 850 nM
Compound 4: middle estimate off by 2.4-fold (0.37 log units), on the high side; measured number inside the range.
By their numbers in this assay, from the lowest: compounds 4 and 3 (each within the scatter of the next); then compounds 1 and 2 (each within the scatter of the next).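

In this assay, among these compounds, ethoxy on this aromatic carbon stands clear of both hydrogen, with a 4.6-fold lower number from compound 1 to compound 4 (0.66 log units; beyond the scatter), and fluoro, with a 5.6-fold lower number from compound 2 to compound 4 (0.75 log units; beyond the scatter), so methyl is no longer the only group here that separates from those two. Ethoxy and methyl themselves cannot be told apart, with a 1.8-fold lower number from compound 3 to compound 4 (0.25 log units; within the scatter), so adding the oxygen and the longer chain at this place gives no step beyond the scatter relative to methyl. Nothing available explains why compounds 3 and 4 sit apart from compounds 1 and 2.

From the compounds shown here alone, it remains open whether a longer chain such as butoxy would extend this trend or reverse it. Going by these compounds, the response of this place to an amine or a carboxylic acid, and whether ethyl would match ethoxy, also remains open.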